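Notes on a methoxy for methyl exchange

A few compounds are considered here, and "the series" means these few. Any claim that something is new, unique, unknown or untested is made for them only; others in the source may bear on it.

Values in an ADME assay on L6 cells (Rattus norvegicus) for cytotoxicity, read by resazurin assay, with a stated time of 70 h (a higher number here means a weaker inhibitor, a lower number a stronger inhibitor), so far
- compound 1 (`CC1=CC(C)(C)N(Cc2ccc(Cl)cc2)c2ccc(O)cc21`) gives 7900 nM
- compound 2 (`CC1=CC(C)(C)N(Cc2ccc(C)cc2)c2ccc(O)cc21`) gives 8100 nM

Only these two numbers are available, and they lie within the scatter of each other, so compound 2 stands level with compound 1. The next compound is compound 3 (`COc1ccc(CN2c3ccc(O)cc3C(C)=CC2(C)C)cc1`), which has not yet been measured. Its difference from compound 2 is methoxy in place of methyl on an aromatic carbon in one exchange, methoxy in place of methyl on an aromatic carbon, para to a large group.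

Within the data shown here, one measured step bears on this exchange. It is a 1.0-fold higher number from compound 1 to compound 2 (0.01 log units; within the scatter) for methyl in place of chloro on an aromatic carbon. Among the measured compounds shown here, no measured compound carries methoxy, so this single step gives only thin support and the range is kept wider than the scatter. On that step, no change beyond the scatter is expected in this assay for the new exchange. The estimated step is a 1.0-fold lower number from compound 2 to compound 3 (0.01 log units; within the scatter) on this reasoning. For compound 3 the estimated value is 8000 nM with an expected range from 4000 nM to 16000 nM for this measurement.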

Compound 3, half-maximal inhibitory concentration: 6200 nM
For compound 3 the middle estimate is 1.3-fold (0.11 log units) above the measured one; low and high end bracket the measured number.
By their numbers in this assay, from the lowest: compounds 3, 1 and 2 (each within the scatter of the next).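

Working notes on the aromatic carbon para to a large group: methoxy is the first group here to bring a hydrogen-bond acceptor, and in this assay the exchange for methyl gives a 1.3-fold lower number from compound 2 to compound 3 (0.12 log units; within the scatter) while the exchange for chloro gives a 1.3-fold lower number from compound 1 to compound 3 (0.11 log units; within the scatter) in the same series. Chloro, methyl and methoxy therefore all read within the scatter of one another at this position, which the earlier pair could show only for chloro and methyl, and the extra heavy atom of methoxy with its oxygen does not carry the number beyond that scatter. No measurement is at hand that would explain why these three groups read alike.

From the compounds shown here alone, it remains open whether this position stays as flat in this assay with an amine, a carboxylic acid or a chain longer than methoxy in place of these small groups. Going by these compounds, all three compounds also keep the shared core and its hydroxy group unchanged, so the response to an exchange at that hydroxy group is equally open.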